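The source may hold more compounds than are shown below. What is called first, only, known or untested is meant among the compounds shown, and "the series" means these compounds.

Working notes on the thiosemicarbazone series.

Compound 1 `S=C(N/N=C\c1ccccc1)N(Cc1ccccc1)Cc1ccccc1` gives 174000 nM in an ADME assay on Vero cells (Chlorocebus sabaeus) for cytotoxicity, read by MTT assay, with a stated time of 72 h; on this read-out higher numbers stand for lower toxicity in this test and lower numbers for higher toxicity in this test. Compound 3 `C/C(=N/NC(=S)N(Cc1ccccc1)Cc1ccccc1)c1ccccc1` gives 167000 nM in this assay; the step of a 1.0-fold lower number from compound 1 to compound 3 (0.02 log units; within the scatter) goes with the core difference (a group of 9 heavy atoms (8 carbon, 1 nitrogen; one six-membered aromatic ring of carbon only) in place of a group of 8 heavy atoms (7 carbon, 1 nitrogen; one six-membered aromatic ring of carbon only), on an amide-type nitrogen), and the two values sit within the scatter of each other. Compound 2 `O=[N+]([O-])c1ccc(/C=N\NC(=S)N(Cc2ccccc2)Cc2ccccc2)cc1` is reported in this assay only as a limit, < 155000 nM. As far as these compounds go, the step of an at least 1.1-fold lower number from compound 1 to compound 2 (0.05 log units; that floor lies within the scatter) corresponds to the change (nitro in place of hydrogen on an aromatic carbon); it rests on (the limit of < 155000 nM in this assay, at which 1 of the 3 values shown sits), so its true size is unknown. Compound 4 `C/C(=N/NC(=S)N(Cc1ccccc1)Cc1ccccc1)c1ccc([N+](=O)[O-])cc1` carries the same change, (nitro in place of hydrogen on an aromatic carbon), on the core of compound 3; the two place lines read alike. From compound 3 the step is expected to be a 1.1-fold lower number from compound 3 to compound 4 (0.05 log units; within the scatter), taken from the step from compound 1 to compound 2. Compound 4 is therefore estimated at 150000 nM in this assay, expected between 100000 nM and 200000 nM, with a fair chance that only a limit is reported.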

Compound 4, half-maximal cytotoxic concentration: < 150000 nM
Compound 4 ended at the assay's limit (the forecaster's own chance of this, stated with the estimate: 50%); the middle value sits exactly at the limit.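

In this assay, phenyl to 4-nitrophenyl on the core of compound 3 gives an at least 1.1-fold lower number from compound 3 to compound 4 (0.04 log units; that floor lies within the scatter). For compound 4, < 150000 nM is a limit of the assay and not a number. The nitro change can thus be set side by side on the two cores only through these floors, and the data do not show whether its size carries from one core to the other: the same change on two cores in this assay, an at least 1.1-fold lower number (0.05 log units; that floor lies within the scatter) from compound 1 to compound 2 and an at least 1.1-fold lower number (0.04 log units; that floor lies within the scatter) from compound 3 to compound 4; the limit leaves it open whether they differ

Still open, as far as these compounds go, is whether a group such as an amine or a carboxylic acid in place of that aromatic hydrogen would give a number rather than a limit in this assay. Also open, from the compounds shown here alone, is whether any change at that place moves the read-out beyond the scatter.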